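Swapping the Aryl Group on a Pyrrolidine-Bearing Analogue

The source may hold more compounds than are shown below. What is called first, only, known or untested is meant among the compounds shown, and "the series" means these compounds.

Three compounds sharing one core were tested in a functional assay on MKN-45 cells (Homo sapiens) for cytotoxicity, read by MTT assay, with a stated time of 72 h; a higher number here means a weaker inhibitor, a lower number a stronger inhibitor. Compound 1 `COc1cc2c(Oc3ccc(NC(=O)c4cc(-c5ccccc5C)ccn4)cc3F)ccnc2cc1OCCCN1CCN(C)CC1` gives 240 nM, compound 2 `COc1cc2c(Oc3ccc(NC(=O)c4cc(-c5ccc(C(F)(F)F)cc5)ccn4)cc3F)ccnc2cc1OCCCN1CCN(C)CC1` gives 330 nM, and compound 3 `COc1cc2c(Oc3ccc(NC(=O)c4cc(-c5ccccc5C)ccn4)cc3F)ccnc2cc1OCCCN1CCCC1` gives 440 nM. Compound 3 thus carries the largest number of the three, although its gaps to compound 2 and compound 1 are both within the usual scatter. Compound 4 `COc1cc2c(Oc3ccc(NC(=O)c4cc(-c5ccc(C(F)(F)F)cc5)ccn4)cc3F)ccnc2cc1OCCCN1CCCC1` differs from compound 3 by 4-(trifluoromethyl)phenyl in place of 2-methylphenyl on an aromatic carbon. The same change has been seen once already: a 1.4-fold higher number from compound 1 to compound 2 (0.14 log units; within the scatter). Carrying that small shift over to compound 3, a step of a 1.3-fold higher number from compound 3 to compound 4 (0.12 log units; within the scatter) is expected in this assay, not beyond the scatter. Compound 4 is therefore estimated at 580 nM, plausibly between 300 nM and 1100 nM.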

Compound 4, half-maximal inhibitory concentration: 260 nM
For compound 4 the middle estimate is 2.2-fold (0.35 log units) above the measured one; the whole stated range lies above it.
By their numbers in this assay, from the lowest: compounds 1, 4, 2 and 3 (each within the scatter of the next).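

The second reading of this change, on the carbon opposite the ring nitrogen, is a 1.7-fold lower number from compound 3 to compound 4 (0.23 log units; within the scatter) and leaves 2-methylphenyl and 4-(trifluoromethyl)phenyl indistinguishable on either core: the same change on two cores in this assay, a 1.4-fold higher number (0.14 log units; within the scatter) from compound 1 to compound 2 and a 1.7-fold lower number (0.23 log units; within the scatter) from compound 3 to compound 4, 2.3-fold (0.37 log units) apart, within the scatter of two such steps. The swap of 4-methylpiperazin-1-yl for pyrrolidin-1-yl also gains a second reading, a 1.3-fold lower number from compound 2 to compound 4 (0.10 log units; within the scatter) and likewise shows no separation beyond the scatter: the same change on two cores in this assay, a 1.8-fold higher number (0.26 log units; within the scatter) from compound 1 to compound 3 and a 1.3-fold lower number (0.10 log units; within the scatter) from compound 2 to compound 4, 2.3-fold (0.37 log units) apart, within the scatter of two such steps. All four compounds therefore tolerate both changes equally within this scatter. Going by these compounds, whether a carboxylic acid or an amine on the phenyl ring, in place of trifluoromethyl, would produce a step beyond the scatter remains open.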